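Swapping a carboxyphenyl for azepane: human microsomal half-life

A few compounds are considered here, and "the series" means these few. Any claim that something is new, unique, unknown or untested is made for them only; others in the source may bear on it.

Compound 1 `CCc1nc2ccc(Cl)cn2c1C(=O)NCc1ccc(-c2ccc(C#N)cc2)cc1`: > 2 h
Compound 2 `CCc1nc2cc(Cl)ccn2c1C(=O)NCc1ccc(-c2ccc(C(=O)O)cc2)cc1`: > 2 h

The two measured compounds were tested in an ADME assay (liver) for metabolic stability, with Liver microsome (Homo sapiens) as the target, using microsomes; a lower number here means that the compound disappears faster, a higher number that the compound lasts longer. There compound 2 gives > 2 h, which is a limit of the assay and not a number. Compound 1 gives > 2 h, also a limit. Among the measured compounds shown here, the record so far is therefore (the limit of > 2 h in this assay, at which 2 of the 2 values shown sit), and no measured pair shows how large a single structural change can be here.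

Compound 3 `CCc1nc2cc(Cl)ccn2c1C(=O)NCc1ccc(N2CCCCCC2)cc1` departs from compound 2 in one place, (azepan-1-yl in place of 4-carboxyphenyl on an aromatic carbon), with azepan-1-yl in place of 4-carboxyphenyl on an aromatic carbon, para to a large group. For the measured compounds named here, the data hold no precedent for this exchange, so any forecast is loose. A fall in half-life beyond the scatter is expected, though a result at the same limit remains possible. This expectation rests on compound 2 at > 2 h, again a limit, and on the whole 4-carboxyphenyl leaving. The expected change is an at least 2.2-fold lower number from compound 2 to compound 3 (0.34 log units; beyond the scatter), and this size is only an estimate. For compound 3 the estimated half-life is 0.9 h, with an expected range from 0.3 h to 2 h.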

Compound 3, half-life: 0.0483 h
Beside the measured number, compound 3's estimate is 19-fold (1.27 log units) above it, outside the stated range (below it).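

In this assay, among the compounds shown here, azepan-1-yl in place of 4-carboxyphenyl gives an at least 41-fold lower number from compound 2 to compound 3 (1.61 log units; beyond the scatter), the first step that can be read, and it shows that the half-life depends strongly on what sits at this aromatic carbon, para to a large group. Compound 2 gives > 2 h, which is a limit of the assay, and the step therefore marks only the smallest change consistent with the data, not its full size. Compound 3 is now the only compound shown whose value lies off that limit, which the earlier compounds could not provide: the limit of > 2 h in this assay, at which 2 of the 3 values shown sit.

The exchange removes the six-membered aromatic ring and the carboxylic acid together and brings in a seven-membered non-aromatic ring with a nitrogen, and the compounds shown do not tell which of these parts accounts for the fall in half-life. An unsubstituted phenyl group at this place would address the role of the carboxylic acid, and a piperidine ring would test whether the shorter half-life is specific to the azepane ring.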